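A few compounds are considered here, and "the series" means these few. Any claim that something is new, unique, unknown or untested is made for them only; others in the source may bear on it.

Compound 1, with the structure `COC(=O)C1=C(C)NC(=S)NC1c1cccs1`, compound 2, with the structure `CCCOC(=O)C1=C(C)NC(=S)NC1c1cccs1`, and compound 3, with the structure `COC(=O)C1=C(C)N(C)C(=O)NC1c1cccs1`, have all been tested; compound 4, with the structure `CCCOC(=O)C1=C(C)N(C)C(=O)NC1c1cccs1`, has not.

In an assay on membranes from HEK293 cells for displacement of a labelled ligand from adenosine receptor A2b (Homo sapiens), read by scintillation counting, with a stated time of 30 min, tested at 1 uM (on this read-out higher numbers stand for more inhibition at the one concentration tested (going by the name of the read-out) and lower numbers for less inhibition), compound 1 gives 10%. Compound 2 gives 3% in this assay. The two differ only in one place, (ethyl in place of hydrogen on a saturated chain carbon bound to an oxygen next to a carbonyl group), and that change gave a number 7 percentage points lower from compound 1 to compound 2 (within the scatter).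

In this assay compound 3 gives 17%. Compound 3 and compound 1 differ in more than one place, and the difference between the two cores is not broken down here.

Compound 4 differs from compound 3 in the same way, (ethyl in place of hydrogen on a saturated chain carbon bound to an oxygen next to a carbonyl group), at a place described in the same words, so it is the same change made on the core of compound 3. Because a number 7 percentage points lower from compound 1 to compound 2 (within the scatter) stayed within the scatter, a step of similar size is expected here too, namely a number 6 percentage points lower from compound 3 to compound 4 (within the scatter). On that basis compound 4 is expected to give about 11% in this assay, most likely somewhere between 0% and 24%.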

Compound 4, a percentage reported as inhibition, at one concentration (the size of the read-out at that concentration, not a potency): 1%
Compound 4: middle estimate off by 10 percentage points, on the high side; low and high end bracket the measured number.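

On the core of compound 3, propoxycarbonyl in place of methoxycarbonyl gives a clear drop in this assay (a number 16 percentage points lower from compound 3 to compound 4 (beyond the scatter)). Going by these compounds alone, this is the only step of the pair that stands clear of the usual scatter, and all of these numbers are inhibition at a single concentration, so they do not give potencies and say little about how large the change would be on any other core. Set side by side, the steps show that the change carries across these two cores without a detectable difference in size, though two pairs cannot establish a rule for the series: the same change on two cores in this assay, a number 7 percentage points lower (within the scatter) from compound 1 to compound 2 and a number 16 percentage points lower (beyond the scatter) from compound 3 to compound 4, 9 percentage points apart, within the scatter of two such steps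

The compounds shown leave open what other groups would do in this place, such as a longer chain like butoxycarbonyl, a carboxylic acid or an amide. They also leave open whether the same change would behave alike on a third core.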